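The source may report more compounds than this note shows. Statements on the series, on what has been measured and on what is new or still open speak of the compounds shown alone.

Compound 1 `Cc1ccc(S(=O)(=O)/N=C(/CCNC2=CC(=O)c3ccccc3C2=O)Nc2cccc(C(F)(F)F)c2)cc1` carries a 3-(trifluoromethyl)phenyl group on an amine nitrogen. Within the data shown here, in a functional assay on A549 cells (Homo sapiens) for cytotoxicity, read by MTT assay, with a stated time of 48 h (on this read-out lower numbers stand for stronger inhibition and higher numbers for weaker inhibition), compound 1 gives 78500 nM, the higher of the two numbers measured so far. Among the measured compounds shown here, compound 2 `COc1ccc(N/C(CCNC2=CC(=O)c3ccccc3C2=O)=N\S(=O)(=O)c2ccc(C)cc2)cc1OC`, the only other measured compound, gives 20500 nM in this assay, and the single measured step is a 3.8-fold lower number from compound 1 to compound 2 (0.58 log units; beyond the scatter). Compound 3 `Cc1ccc(S(=O)(=O)/N=C(/CCNC2=CC(=O)c3ccccc3C2=O)Nc2cc(F)c(F)c(F)c2)cc1` differs from compound 1 by 3,4,5-trifluorophenyl in place of 3-(trifluoromethyl)phenyl on an amine nitrogen. Since this change also swaps the ring on the amine nitrogen, a modest lowering is expected because a 3.8-fold lower number from compound 1 to compound 2 (0.58 log units; beyond the scatter) went that way, though a different ring enters here, so the expectation is loose. The expected step is a 1.7-fold lower number from compound 1 to compound 3 (0.24 log units; within the scatter). Compound 3 is expected to give 45000 nM, with a range of 15000 nM to 140000 nM.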

Compound 3, half-maximal inhibitory concentration: 10200 nM
Beside the measured number, compound 3's estimate is 4.4-fold (0.64 log units) above it, and the stated range ends above it.
By their numbers in this assay, from the lowest: compounds 3 and 2 (each within the scatter of the next); then compound 1.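

Putting 3,4,5-trifluorophenyl on the amine nitrogen gives a 7.7-fold lower number from compound 1 to compound 3 (0.89 log units; beyond the scatter) in this assay and so shows that a second replacement for 3-(trifluoromethyl)phenyl also lowers the number. The two replacements cannot be separated in this assay, with a 2.0-fold lower number from compound 2 to compound 3 (0.30 log units; within the scatter) as the step between them. No measurement here explains these differences.

As far as these compounds go, it remains open whether an unsubstituted phenyl ring would group with compound 2 and compound 3 or with compound 1. The same question applies to a phenyl ring carrying a carboxylic acid.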